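Chloro in place of fluoro: clearance outlook for compound 3

A few compounds are considered here, and "the series" means these few. Any claim that something is new, unique, unknown or untested is made for them only; others in the source may bear on it.

In an in vitro ADME assay on microsomes from liver (Mus musculus) for pharmacokinetics, read by LC-MS, with a stated time of 10 min, tested at 1 uM (on this read-out higher numbers stand for fast clearance and lower numbers for slow clearance), compound 1 (`COc1ccc(NC(=O)[C@H]2CN(C)C[C@@H]2c2ccc(/C=C/C(=O)Nc3ccccc3N)cc2)cc1`) gives 54 mL/min/kg and compound 2 (`CN1C[C@H](C(=O)Nc2cccc(F)c2)[C@@H](c2ccc(/C=C/C(=O)Nc3ccccc3N)cc2)C1`) gives 56 mL/min/kg within the scatter of compound 1, so compound 2 stands level with compound 1 on the numbers available. Among the compounds with values here, the one measured step of a 1.0-fold higher number from compound 1 to compound 2 (0.02 log units; within the scatter) puts 3-fluorophenyl in place of 4-methoxyphenyl on an amide-type nitrogen.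

Compound 3 (`CN1C[C@H](C(=O)Nc2cccc(Cl)c2)[C@@H](c2ccc(/C=C/C(=O)Nc3ccccc3N)cc2)C1`) differs from compound 2 by chloro in place of fluoro on an aromatic carbon, meta to a large group (chloro in place of fluoro on an aromatic carbon). Within the data shown here, no measured compound carries chloro, so the only guide is the change at the same amide-type nitrogen, the step of a 1.0-fold higher number from compound 1 to compound 2 (0.02 log units; within the scatter) that stayed within the scatter. One step is thin evidence, but it gives no reason to expect a shift beyond the scatter in this assay here. The estimated move is a 1.0-fold higher number from compound 2 to compound 3 (0.02 log units; within the scatter) and nothing larger is expected. For compound 3 the expected clearance is 58 mL/min/kg with an estimated range from 33 mL/min/kg to 95 mL/min/kg on this basis.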

Compound 3, clearance: 58 mL/min/kg
Compound 3: middle estimate and measured number agree at the digits printed, within the range that was stated.
By their numbers in this assay, from the lowest: compounds 1, 2 and 3 (each within the scatter of the next).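

In this assay, within the data shown here, chloro in place of fluoro on an aromatic carbon, meta to a large group, gives a 1.0-fold higher number from compound 2 to compound 3 (0.02 log units; within the scatter); this is the first reading of a change of a single atom on this ring, where the earlier step exchanged the whole group on the amide-type nitrogen. With a 1.1-fold higher number from compound 1 to compound 3 (0.03 log units; within the scatter), which puts 3-chlorophenyl in place of 4-methoxyphenyl, the 4-methoxyphenyl, 3-fluorophenyl and 3-chlorophenyl groups on that nitrogen cannot be told apart on this read-out, and the halogen at this place makes no difference beyond the scatter. Nothing available offers an explanation for this flat picture.

The compounds shown leave open whether any group on the amide-type nitrogen can move clearance beyond the scatter, for instance a phenyl carrying a carboxylic acid, a dimethylamino group or a trifluoromethyl group, or a plain cyclohexyl in place of the aromatic ring. They also leave open whether the same flat picture would hold with a longer chain in place of the methyl on the nitrogen of the core.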